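Flipping One Stereocentre in a Chemokine Receptor Binder

The source may report more compounds than this note shows. Statements on the series, on what has been measured and on what is new or still open speak of the compounds shown alone.

Compound 1, `C[C@@H](NC(=O)[C@H](CCCNC(=N)N)NC(=O)c1ccc(CN(Cc2ccc(F)cc2)Cc2ccccn2)cc1)c1cccc2ccccc12`, was tested in an assay on Jurkat cells for displacement of a labelled ligand from C-X-C chemokine receptor type 4 (Homo sapiens), tested at 10 uM (on this read-out higher numbers stand for more inhibition at the one concentration tested (going by the name of the read-out) and lower numbers for less inhibition), where compound 1 gives 0%. This is the lowest of the three numbers recorded, but the other two compounds sit within the usual scatter of it, so no real order among them can be read. Compound 2, `C[C@@H](NC(=O)[C@H](CCCNC(=N)N)NC(=O)c1ccc(CN(Cc2ccc(F)cc2)Cc2cccnc2)cc1)c1cccc2ccccc12`, gives 6% in this assay, and the change a number 6 percentage points higher from compound 1 to compound 2 (within the scatter). Compound 3, `C[C@@H](NC(=O)[C@H](CCCNC(=N)N)NC(=O)c1ccc(CN(Cc2ccccn2)C(=O)c2ccc(F)cc2)cc1)c1cccc2ccccc12`, gives 3%, with the change a number 3 percentage points higher from compound 1 to compound 3 (within the scatter).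

Compound 4, `C[C@H](NC(=O)[C@H](CCCNC(=N)N)NC(=O)c1ccc(CN(Cc2ccc(F)cc2)Cc2ccccn2)cc1)c1cccc2ccccc12`, shares every atom and bond with compound 1: the two compounds have the same atoms and bonds; at least one stereo element is drawn with a configuration in one of them and without one in the other: 1 of 3 stereo elements differ; a stereocentre at a saturated chain carbon is drawn R in compound 1 and S in compound 4. Neither measured step bears directly on this kind of change, since both altered a substituent rather than the drawn configuration at a stereocentre, and both stayed within the scatter. Going by the values given here, with all three measured numbers sitting close to zero, and no measured step having moved the read-out beyond the scatter, no step beyond the scatter is expected here either. Compound 4 is therefore expected to give about 3% in this assay, within a range of 0% to 12%. The expected step is a number 3 percentage points higher from compound 1 to compound 4 (within the scatter).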

Compound 4, a percentage reported as inhibition, at one concentration (the size of the read-out at that concentration, not a potency): 30%
Compound 4: the middle estimate sits 27 percentage points below what was measured; the measured number lies above the stated range.
By their numbers in this assay, from the lowest: compounds 1, 3 and 2 (each within the scatter of the next); then compound 4.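

Turning a single stereocentre at a saturated chain carbon from R to S, with no atom or bond altered, gives a number 30 percentage points higher from compound 1 to compound 4 (beyond the scatter) in this assay. Compounds 1, 2 and 3 had all stayed within the scatter of one another despite changes to the pyridine and to the 4-fluorobenzyl group, so they gave no sign that this series could register at all in the assay, whereas this step shows that it can, and that the drawn configuration at this one carbon is enough to move the number. The pair offers only one recorded difference to attach the step to, and it lies at that carbon: the fact that one of compounds 1 and 4 is drawn with a defined configuration and the other without, at the place where they differ

The compounds shown leave open whether pyridin-3-yl or the (4-fluorophenyl)carbonyl group would change the number once the S configuration is in place, since both were seen only alongside R, where the numbers were too close to zero to separate them. They also leave open how a carboxylic acid in place of 4-fluorobenzyl on the amine nitrogen would behave, and whether any such change would take the modest inhibition of compound 4 further.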